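Working notes: chloro in place of hydrogen on two cores

This account rests on a few compounds, and the source may have more. Where it says the series, first, only, none or still open, it means among the compounds named here.

Measured so far:
compound 1 `O=S(=O)(c1ccc2cccnc2c1)n1cc(C2=CCNCC2)c2ccccc21` — 7 nM
compound 2 `O=S(=O)(c1cncc2ccccc12)n1cc(C2=CCNCC2)c2ccccc21` — 5 nM
compound 3 `O=S(=O)(c1cncc2ccccc12)n1cc(C2=CCNCC2)c2cc(Cl)ccc21` — 18 nM

In an assay on HEK293 cells for displacement of a labelled ligand from 5-hydroxytryptamine receptor 6 (Homo sapiens), read by scintillation counting (a higher number here means a weaker inhibitor, a lower number a stronger inhibitor), compound 2 gives 5 nM and compound 1 gives 7 nM; the two values lie within the scatter of each other. The difference between the two cores is not broken down here. Compound 3 carries chloro in place of hydrogen on an aromatic carbon, and the result is a 3.6-fold higher number from compound 2 to compound 3 (0.56 log units; beyond the scatter).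

Compound 4 `O=S(=O)(c1ccc2cccnc2c1)n1cc(C2=CCNCC2)c2ccc(Cl)cc21` is built on the core of compound 1 with chloro in place of hydrogen on an aromatic carbon. The place is described in the same words for both cores, so this is the same change, here repeated on the other core. For the measured compounds named here, the step from compound 1 to compound 4 in this assay is expected to be a 3.1-fold higher number from compound 1 to compound 4 (0.50 log units; beyond the scatter), resting on a 3.6-fold higher number from compound 2 to compound 3 (0.56 log units; beyond the scatter) as the only guide. For compound 4 the estimated value is 22 nM, expected to fall between 10 nM and 50 nM.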

Compound 4, inhibition constant: 22 nM
Beside the measured number, compound 4's estimate shows no gap at the digits printed, and the stated range covers the measured number.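

In this assay, chloro in place of hydrogen on an aromatic carbon gives a 3.1-fold higher number from compound 1 to compound 4 (0.50 log units; beyond the scatter), and the step carries from one core to the other with no difference beyond the scatter: the same change on two cores in this assay, a 3.6-fold higher number (0.56 log units; beyond the scatter) from compound 2 to compound 3 and a 3.1-fold higher number (0.50 log units; beyond the scatter) from compound 1 to compound 4, 1.1-fold (0.06 log units) apart, within the scatter of two such steps

This agreement rests on a single pair of cores and sets no rule for other cores in the series. The chloro also stands on a different ring carbon in compound 3 and compound 4, so the pair does not show how the step depends on its place.

Going by these compounds, whether fluoro or methoxy in place of hydrogen would carry across the two cores in the same way remains open. So does the effect of a methyl group on the ring amine.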